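The source may hold more compounds than are shown below. What is called first, only, known or untested is meant among the compounds shown, and "the series" means these compounds.

For the measured compounds named here, compound 3 `Fc1cc2c(-c3ccc4c(C(F)(F)F)cccc4n3)c[nH]c2c(F)c1F` sits with compound 1 `CNC(=O)c1cccc2nc(-c3c[nH]c4c(F)c(F)c(F)cc34)ccc12` at the long-lasting end of the three compounds measured so far. In an ADME assay on microsomes from liver (Homo sapiens) for metabolic stability, using NADPH, with a stated time of 40 min, tested at 2 uM (a lower number here means that the compound disappears faster, a higher number that the compound lasts longer), compound 3 gives 1.12 h, and compound 1 gives 1.17 h. Compound 2 `Fc1ccc2c(-c3ccc4ccccc4n3)c[nH]c2c1F` gives 0.167 h, a far lower number, although it differs from compound 3 in two places rather than one.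

Compound 4 `Fc1cc2c(-c3ccc4ccccc4n3)c[nH]c2c(F)c1F` is reached from compound 3 by a single change: hydrogen in place of trifluoromethyl on an aromatic carbon. Going by the values given here, only one measured step is available, and it does not reproduce this change. The step of a 1.0-fold lower number from compound 1 to compound 3 (0.02 log units; within the scatter) exchanges one group for another at the same place and leaves the half-life essentially unchanged. Among the compounds with values here, no measured step removes a group from that place altogether. Compound 2, which carries hydrogen at the same place but also one fluorine fewer, is the only hint, and its number lies well below that of compound 3.

The expectation for compound 4 is therefore a shorter half-life than compound 3, with the step of a 3.2-fold lower number from compound 3 to compound 4 (0.51 log units; beyond the scatter) estimated to be beyond the scatter but smaller than the gap down to compound 2. Compound 4 is expected to give about 0.35 h in this assay, with a range from 0.15 h to 0.9 h.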

Compound 4, half-life: 0.25 h
Compound 4: the middle estimate sits 1.4-fold (0.15 log units) above what was measured; the measured number falls inside the stated range.
By their numbers in this assay, from the lowest: compounds 2 and 4 (each within the scatter of the next); then compounds 3 and 1 (each within the scatter of the next).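

In this assay, leaving this aromatic carbon with only hydrogen now has a measured price: trifluoromethyl gives way to hydrogen in a 4.5-fold lower number from compound 3 to compound 4 (0.65 log units; beyond the scatter), and methylcarbamoyl gives way to hydrogen in a 4.7-fold lower number from compound 1 to compound 4 (0.67 log units; beyond the scatter). Read with the earlier exchange of one group for the other (a 1.0-fold lower number from compound 1 to compound 3 (0.02 log units; within the scatter)), these steps show that in these compounds, having either group at this place matters more to the half-life than which of the two it is. The short half-life of compound 2 also looks less tied to its missing fluorine, as fluoro in place of hydrogen on another aromatic carbon of the core gives only a 1.5-fold higher number from compound 2 to compound 4 (0.18 log units; within the scatter), leaving hydrogen at the place under study as the feature that compounds 2 and 4 share.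

Nothing available explains why these two groups go with a longer half-life than hydrogen. As far as these compounds go, whether the same holds for a small methyl, an amine or a carboxylic acid at this place remains open, as do the effects of these groups on a core with fewer fluorines.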